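A few compounds are considered here, and "the series" means these few. Any claim that something is new, unique, unknown or untested is made for them only; others in the source may bear on it.

Among the compounds with values here, compound 1 `Cc1ccc(Nc2nc(N)nc(COc3cccc(N4CCCC4=O)c3)n2)cc1Cl` is one of only two compounds in this set with a number in an assay on COS-7 cells for agonist activity at Free fatty acid receptor 1 (Homo sapiens), read by scintillation counting and inositol phosphate accumulation, with a stated time of 90 min; on this read-out higher numbers stand for an effect only at larger amounts of compound and lower numbers for an effect already at smaller amounts; in this assay compound 1 gives 820 nM and has the lowest of the two numbers. Compound 2 `COc1cc(OCc2nc(N)nc(Nc3ccc(C)c(Cl)c3)n2)cc(N2CCCC2=O)c1` carries a methoxy in place of hydrogen on an aromatic carbon, and in this assay compound 2 gives 1800 nM; the step of a 2.2-fold higher number from compound 1 to compound 2 (0.34 log units; beyond the scatter) is modest. Compound 3 `Cc1ccc(Nc2nc(N)nc(COc3cc(N4CCCC4=O)cc(C(C)(C)C)c3)n2)cc1Cl` has no result reported in this assay: for compound 3 the entry reads "not determined" (no result reported).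

Compound 4 `Cc1ccc(Nc2nc(N)nc(COc3cc(N4CCCC4=O)ccc3C)n2)cc1Cl` differs from compound 1 by methyl in place of hydrogen on an aromatic carbon. Within the data shown here, the only measured step that bears on this change is the one from compound 1 to compound 2, which also added a small group on an aromatic carbon of that part of the molecule and gave a modest rise in the number; the methyl of compound 4 sits at a different place, so this step is only a loose guide. On that basis, a small rise in the number, or none beyond the scatter, is expected for compound 4, that is, a 1.3-fold higher number from compound 1 to compound 4 (0.13 log units; within the scatter). Compound 4 is therefore estimated at 1100 nM in this assay, with a range from 400 nM to 3200 nM.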

Compound 4, half-maximal effective concentration: 7450 nM
Beside the measured number, compound 4's estimate is 6.8-fold (0.83 log units) below it; measured number outside the range, above it.
By their numbers in this assay, from the lowest: compound 1; then compound 2; then compound 4.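

In this assay this carbon, ortho to a large group and para to a 2-oxopyrrolidin-1-yl group, turns out to be sensitive: adding one methyl, a single heavy atom with no charge, gives a 9.1-fold higher number from compound 1 to compound 4 (0.96 log units; beyond the scatter). This step is larger than the earlier 2.2-fold higher number from compound 1 to compound 2 (0.34 log units; beyond the scatter), so on this ring a small addition at one carbon does not predict the result at another, although the two steps also differ in the group added. Nothing measured here gives a reason for the rise.

One methyl at one carbon cannot show whether the number follows the size of the added group or is particular to methyl. A fluorine, a chlorine or a hydroxyl at this same carbon would help to tell these two readings apart.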